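Replacing an Aryl Arm with a Hydroxyethoxy Chain

The compounds below may be only part of what the source reports. "The series", "measured", "known", "first", "only" and "open" are said of these compounds alone.

Of the compounds shown here, three have been measured in an assay on cell membranes for binding affinity to Neuronal acetylcholine receptor; alpha4/beta2 (Rattus norvegicus), read by radioligand binding; a lower number here means a stronger inhibitor, a higher number a weaker inhibitor. Compound 1 `CCOc1cncc(N2CCNCC2)c1` gives 500 nM. Compound 2 `c1cncc(-c2cncc(N3CCCNCC3)c2)c1` gives 2.8 nM, the lowest of the three numbers. Compound 3 `c1ccc(Sc2cncc(N3CCCNCC3)c2)cc1` gives 4 nM; its value and that of compound 2 lie within the scatter of each other, while the value of compound 1 stands well beyond the scatter from that of compound 2.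

Compound 4 `OCCOc1cncc(N2CCCNCC2)c1` has not been measured. It differs from compound 2 in one place: 2-hydroxyethoxy in place of pyridin-3-yl on an aromatic carbon. Among the measured compounds shown here, no pair of measured compounds differs in exactly this way, so the size of the step is open. For the measured compounds named here, the only measured compound that carries an alkoxy group on the aromatic carbon is compound 1, and its structure differs from compound 4 in more than one place. The value of compound 1, 500 nM, can therefore serve only as a rough pointer. Compound 4 is expected to give a higher number than compound 2, a step of a 54-fold higher number from compound 2 to compound 4 (1.73 log units; beyond the scatter) that lies beyond the scatter. The estimate for compound 4 in this assay is 150 nM, with a range from 30 nM to 800 nM.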

Compound 4, half-maximal inhibitory concentration: 1.8 nM
The estimate for compound 4 lay 83-fold (1.92 log units) above the measured number; measured number outside the range, below it.
By their numbers in this assay, from the lowest: compounds 4, 2 and 3 (each within the scatter of the next, the first and the last beyond it); then compound 1.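

In this assay, putting 2-hydroxyethoxy in place of pyridin-3-yl on this aromatic carbon, two atoms from the ring nitrogen, gives a 1.6-fold lower number from compound 2 to compound 4 (0.19 log units; within the scatter) and so leaves the number where it was. For this pair, then, an aromatic ring at the position is not required for a low number: a chain with no ring and 4 heavy atoms, against 6 in the group it replaces, does as well. Nothing measured here accounts for this result.

As far as these compounds go, it remains open whether the terminal hydroxyl of the chain matters, which 2-methoxyethoxy or plain ethoxy on the same core would test. A longer chain such as 3-hydroxypropoxy, or an amine-bearing chain such as 2-aminoethoxy, would show how far this position accepts other groups.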